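Methoxy in Place of Methoxycarbonyl: Compound 4 Awaits Measurement

The source may hold more compounds than are shown below. What is called first, only, known or untested is meant among the compounds shown, and "the series" means these compounds.

In a functional assay (aorta) with Rattus norvegicus as the target (a lower number here means a stronger inhibitor, a higher number a weaker inhibitor), compound 3 `COC(=O)c1ccc(N/C(=N/[C@@H]2c3cc(C#N)ccc3OC(C)(C)[C@H]2O)NC#N)cc1` gives 18400 nM, the highest of three numbers and thus the weakest inhibitor so far. Compound 1 `CC1(C)Oc2ccc(C#N)cc2[C@@H](/N=C(\NC#N)Sc2ccccc2)[C@@H]1O` gives 4900 nM, and compound 2 `CC1(C)Oc2ccc(C#N)cc2[C@@H](/N=C(\NC#N)Nc2cccc([N+](=O)[O-])c2)[C@@H]1O` gives 670 nM. Compound 4 `COc1ccc(N/C(=N/[C@@H]2c3cc(C#N)ccc3OC(C)(C)[C@H]2O)NC#N)cc1` differs from compound 3 in one place: methoxy in place of methoxycarbonyl on an aromatic carbon. The closest evidence is a 27-fold higher number from compound 2 to compound 3 (1.44 log units; beyond the scatter), a change of the aryl group on the same amine nitrogen. For the measured compounds named here, the other measured step, a 7.3-fold lower number from compound 1 to compound 2 (0.86 log units; beyond the scatter), bears less directly, and no measured compound carries methoxy. A modest move towards a lower number in this assay is expected, a 3.7-fold lower number from compound 3 to compound 4 (0.57 log units; beyond the scatter). For compound 4 the estimated value is 5000 nM, with an expected range of 1500 nM to 18000 nM.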

Compound 4, half-maximal inhibitory concentration: 32500 nM
Beside the measured number, compound 4's estimate is 6.5-fold (0.81 log units) below it; measured number above the stated range.
By their numbers in this assay, from the lowest: compound 2; then compound 1; then compounds 3 and 4 (each within the scatter of the next).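

Exchanging methoxycarbonyl for methoxy on the aromatic carbon para to a large group gives a 1.8-fold higher number from compound 3 to compound 4 (0.25 log units; within the scatter), so in this assay the two groups cannot be told apart at this position. The 4-methoxyphenyl group also leaves the gaps to the other compounds large or modest, with a 49-fold higher number from compound 2 to compound 4 (1.69 log units; beyond the scatter) and a 6.6-fold higher number from compound 1 to compound 4 (0.82 log units; beyond the scatter). Nothing available here accounts for these numbers.

On these data alone, it remains open whether an amine or a carboxylic acid on that same carbon would read differently from these two groups. As far as these compounds go, it also remains open whether the lower number of compound 2 rests on the nitro group itself or on where it sits.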